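Chloro to Tert-Butyl in a Weak Sigma-2 Triazole Series

A few compounds are considered here, and "the series" means these few. Any claim that something is new, unique, unknown or untested is made for them only; others in the source may bear on it.

The account concerns compound 1 `Cn1nc(CN2CCCC2)nc1-c1ccc(Cl)cc1` in an assay on membranes from Jurkat cells for displacement of a labelled ligand from Sigma intracellular receptor 2 (Homo sapiens), read by scintillation counting, with a stated time of 1 h; on this read-out lower numbers stand for stronger inhibition and higher numbers for weaker inhibition. Compound 1 returns only a limit of the assay, > 1000 nM. Compound 2 `Cc1cc(-c2nc(CN3CCCC3)nn2C)ccc1C(F)(F)F` likewise gives no number but the limit > 1000 nM. Compound 3 `Cn1nc(CN2CCCC2)nc1-c1ccc2cc(Cl)sc2c1` gives 1000 nM. Compound 1 thus stands at the edge of what this assay can read, as shown by the limit of > 1000 nM in this assay, at which 2 of the 3 values shown sit.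

Compound 4 `Cn1nc(CN2CCCC2)nc1-c1ccc(C(C)(C)C)cc1` differs from compound 1 by tert-butyl in place of chloro on an aromatic carbon, on an aromatic carbon of a six-membered aromatic ring of carbon only. No measured pair among these compounds carries such a change, so its direction is open. A modest gain is expected, an at least 1.2-fold lower number from compound 1 to compound 4 (0.09 log units; that floor lies within the scatter), not clearly beyond the scatter. Compound 4 is estimated at 800 nM, between 200 nM and 3000 nM, with a real chance that it too reports only a limit.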

Compound 4, inhibition constant: > 1000 nM
Compound 4: no number, only a limit (the forecaster's own chance of this, stated with the estimate: 45%); middle value at least 1.2-fold (0.09 log units) from the limit.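

Compound 1 and compound 4 each return only a limit in this assay and so no step can be read between them: the limit of > 1000 nM in this assay, at which 3 of the 4 values shown sit. The compounds shown leave open whether tert-butyl in place of chloro changes the inhibition constant at all, and in which direction.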